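From compound 2 to compound 3: one added fluoro

A few compounds are considered here, and "the series" means these few. Any claim that something is new, unique, unknown or untested is made for them only; others in the source may bear on it.

For the measured compounds named here, in an ADME assay on Vero cells (Chlorocebus sabaeus) for cytotoxicity, read by MTT assay, with a stated time of 72 h (a higher number here means that more compound is needed for the effect, a lower number that less compound is needed), compound 2 (`O=C(Nc1nc(-c2ccccn2)cs1)c1ccccc1Cl`) stands at 2000 nM and is the lower of two numbers, with compound 1 (`O=C(Nc1nc(-c2ccccn2)cs1)c1cccc(Br)c1`) at 16100 nM as its only neighbour. Going by the values given here, compound 3 (`O=C(Nc1nc(-c2ccccn2)cs1)c1c(F)cccc1Cl`) brings fluoro in place of hydrogen on an aromatic carbon as its single change, fluoro in place of hydrogen on an aromatic carbon. Among the compounds with values here, the only measured step is an 8.1-fold lower number from compound 1 to compound 2 (0.91 log units; beyond the scatter) and it replaced one substituent with another, so it bears only loosely on an added fluoro. The expected step is a 1.2-fold higher number from compound 2 to compound 3 (0.08 log units; within the scatter) in this assay and no shift beyond the scatter is expected. Compound 3 is estimated at 2400 nM (range 800 nM to 7000 nM).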

Compound 3, half-maximal effective concentration: 1300 nM
Compound 3: middle estimate off by 1.8-fold (0.27 log units), on the high side; the range from low to high includes it.
By their numbers in this assay, from the lowest: compounds 3 and 2 (each within the scatter of the next); then compound 1.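

In this assay, fluoro in place of hydrogen on an aromatic carbon, ortho to a large group and meta to a chloro group, gives a 1.5-fold lower number from compound 2 to compound 3 (0.19 log units; within the scatter), so compound 2 and compound 3 cannot be told apart here. For the compounds shown here, this is the first reading at this position of the ring, and fluoro is tolerated there without a step beyond the scatter. Nothing measured offers an explanation for this result. Still open, from the compounds shown here alone, is whether a methoxy group or an amine at this position would stay equally close to compound 2.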